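This account rests on a few compounds, and the source may have more. Where it says the series, first, only, none or still open, it means among the compounds named here.

Measured so far in an assay on HEK293 cells for agonist activity at Toll-like receptor 8 (Homo sapiens), read by spectrophotometry; a lower number here means that less compound is needed, a higher number that more compound is needed for the effect:
compound 1 `CCCCNc1nc(N)nc(C)c1CCCCc1ccccc1` gives 857 nM
compound 2 `CCCCNc1nc(N)nc(C)c1CCCC(C)(C)O` gives 1220 nM
compound 3 `CCCCNc1nc(N)nc(C)c1CCCc1ccccc1` gives 749 nM

Compound 3 gives the smallest of these three numbers, but the gaps are narrow: a 1.1-fold lower number from compound 1 to compound 3 (0.06 log units; within the scatter) and a 1.6-fold lower number from compound 2 to compound 3 (0.21 log units; within the scatter) are both inside the scatter, so the three compounds cannot be told apart on what has been measured.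

Compound 4 `CCCCNc1nc(N)nc(C)c1CCCCCc1ccccc1` has not yet been measured. It differs from compound 3 in one place: phenethyl in place of phenyl on a saturated chain carbon, three bonds along the chain from an aromatic carbon. Going by the values given here, two measured steps bear on this kind of change at the same place on the chain. The closest is a 1.1-fold lower number from compound 1 to compound 3 (0.06 log units; within the scatter), where a benzyl group gave way to a phenyl group. The other is a 1.4-fold higher number from compound 1 to compound 2 (0.15 log units; within the scatter), where the benzyl group was exchanged for a 1-hydroxy-1-methylethyl group. Neither step reached beyond the scatter, and the same is true of a 1.6-fold lower number from compound 2 to compound 3 (0.21 log units; within the scatter). Three rather different groups at this position thus gave numbers that are indistinguishable from one another.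

On that basis, putting a phenethyl group in place of the phenyl group is expected to leave the number about where it is, and the step of a 1.1-fold higher number from compound 3 to compound 4 (0.03 log units; within the scatter) is the expected outcome. For compound 4 the estimate in this assay is 800 nM, with a range from 400 nM to 1600 nM.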

Compound 4, half-maximal effective concentration: 830 nM
For compound 4 the middle estimate is 1.0-fold (0.02 log units) below the measured one; the measured number falls inside the stated range.
By their numbers in this assay, from the lowest: compounds 3, 4, 1 and 2 (each within the scatter of the next).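

Phenethyl in place of phenyl lengthens the chain that ends in the aromatic ring, and in this assay this gives a 1.1-fold higher number from compound 3 to compound 4 (0.04 log units; within the scatter); the comparison of the two chains that differ by benzyl in place of phenyl, four bonds along the chain from an aromatic carbon, gives a 1.0-fold lower number from compound 1 to compound 4 (0.01 log units; within the scatter). Compound 1, compound 3 and compound 4 therefore extend the earlier comparison to three phenyl-ended chains of different length, and their numbers cannot be told apart. Replacing the hydroxyl-bearing end of the chain tells the same story, with a 1.5-fold lower number from compound 2 to compound 4 (0.17 log units; within the scatter), so the longest phenyl-ended chain shown also cannot be separated from the chain of compound 2, and nothing available here accounts for this lack of separation.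

All four chain ends shown are either a phenyl ring or a 1-hydroxy-1-methylethyl group, so it remains open whether an amine, a carboxylic acid or a much longer chain at this position would also leave the number within the scatter. The compounds also share the rest of their structure, so they say nothing about how changes elsewhere on the shared core would affect this assay.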